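Cyano in Place of Methyl on a Cytotoxicity Limit

This account rests on a few compounds, and the source may have more. Where it says the series, first, only, none or still open, it means among the compounds named here.

Measured compounds:
compound 1 `Cc1ccc2c(c1)nc(-c1ccccc1)n2CCCNc1ccnc2cc(Cl)ccc12` gives > 50000 nM
compound 2 `FC(F)(F)c1ccc2c(c1)nc(-c1ccccc1)n2CCCNc1ccnc2cc(Cl)ccc12` gives 16200 nM

In an ADME assay on CHO cells (Cricetulus griseus) for cytotoxicity, read by MTT assay, with a stated time of 48 h (a higher number here means a weaker inhibitor, a lower number a stronger inhibitor), compound 1 gives > 50000 nM, and this is a limit of the assay rather than a number (the limit of > 50000 nM in this assay, at which 1 of the 2 values shown sits). In the same test compound 2 gives 16200 nM. For the measured compounds named here, the one measured step, an at least 3.0-fold lower number from compound 1 to compound 2 (0.48 log units; beyond the scatter), shows that changing the methyl group on the shared core can move the number beyond the scatter. Compound 3 `N#Cc1ccc2c(c1)nc(-c1ccccc1)n2CCCNc1ccnc2cc(Cl)ccc12` differs from compound 1 by cyano in place of methyl on an aromatic carbon. Going by the values given here, only the step from compound 1 to compound 2 bears on this, and it involves a different entering group, so its size is a loose guide at best. A smaller or comparable move in the same direction is expected, giving an estimated at least 1.6-fold lower number from compound 1 to compound 3 (0.22 log units; that floor lies within the scatter). For compound 3 the expected value is 30000 nM, within 10000 nM to 90000 nM, with a fair chance that only a limit is reported.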

Compound 3, half-maximal inhibitory concentration: 38900 nM
Compound 3: the middle estimate sits 1.3-fold (0.11 log units) below what was measured, within the range that was stated.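

Within this assay, cyano in place of trifluoromethyl gives a 2.4-fold higher number from compound 2 to compound 3 (0.38 log units; beyond the scatter) and so shows what the earlier compounds could not: two different groups replacing methyl at this aromatic carbon need not read alike. Cyano in place of methyl gives an at least 1.2-fold lower number from compound 1 to compound 3 (0.10 log units; that floor lies within the scatter) as its only reading, so this change is not shown to move the number beyond the scatter. Going by these compounds, compound 1 carries a limit rather than a number, and the true size of that step stays unknown because of this: the limit of > 50000 nM in this assay, at which 1 of the 3 values shown sits.

The compounds shown leave open how an amine, a carboxylic acid or a longer chain would read on this same aromatic carbon. They also leave open whether cyano and trifluoromethyl keep this order when the rest of the shared core is changed.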